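The source may report more compounds than this note shows. Statements on the series, on what has been measured and on what is new or still open speak of the compounds shown alone.

Compound 1 `Cn1c(-c2ccc(NC(=O)CSc3nc4ccccc4o3)cc2)nc(-c2ccccc2)c1-c1ccccc1` gives 79.3% in a functional assay on HT-29 cells (Homo sapiens) for cytotoxicity, read by MTT assay, with a stated time of 24 h, tested at 32 ug/mL; a lower number here means a weaker effect, a higher number a stronger effect of the compound at the concentration tested.
Compound 2 `Cn1c(-c2ccc(NC(=O)CSc3nc4cc(Cl)ccc4o3)cc2)nc(-c2ccccc2)c1-c1ccccc1` gives 61.9%.
Compound 3 `Cc1ccc2oc(SCC(=O)Nc3ccc(-c4nc(-c5ccccc5)c(-c5ccccc5)n4C)cc3)nc2c1` gives 59.5%.

On paper the number of compound 3 is the smallest of the three, but the step of a number 2.4 percentage points lower from compound 2 to compound 3 (within the scatter) lies within the scatter, so compound 2 and compound 3 cannot be told apart. Only compound 1 stands clearly apart: a number 19.8 percentage points lower from compound 1 to compound 3 (beyond the scatter), and likewise a number 17.4 percentage points lower from compound 1 to compound 2 (beyond the scatter). Both of those steps show that adding a chloro or a methyl to the 5-methyl-1,3-benzoxazol-2-yl side of the molecule lowers the read-out modestly.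

Compound 4 `Cn1cnnc1SCC(=O)Nc1ccc(-c2nc(-c3ccccc3)c(-c3ccccc3)n2C)cc1` takes a different kind of step. Compared with compound 3, (4-methyl-4H-1,2,4-triazol-3-yl in place of 5-methyl-1,3-benzoxazol-2-yl on a sulfur). Going by the values given here, none of the measured steps exchanges the whole group on the sulfur; they only vary a single substituent on it, so they bear on this change only loosely. They suggest that the read-out is sensitive to what sits on that sulfur, without showing which way a wholesale exchange would go. The expected step is therefore a cautious one: a number 9.5 percentage points lower from compound 3 to compound 4 (within the scatter) is estimated, with a wide range around it. For compound 4 the estimate in this assay is 50%, between 25% and 75%.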

Compound 4, a percentage reported as activity, at one concentration (the size of the read-out at that concentration, not a potency): 86.1%
Compound 4: middle estimate off by 36.1 percentage points, on the low side; the whole stated range lies below it.
By their numbers in this assay, from the lowest: compounds 3 and 2 (each within the scatter of the next); then compounds 1 and 4 (each within the scatter of the next).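

Exchanging the whole group on the sulfur does not have to cost activity in this assay: the 4-methyl-4H-1,2,4-triazol-3-yl group, with one five-membered aromatic ring and no six-membered ring, gives a clearly higher read-out than either substituted benzoxazole, with a number 26.6 percentage points higher from compound 3 to compound 4 (beyond the scatter) and a number 24.2 percentage points higher from compound 2 to compound 4 (beyond the scatter). Against the unsubstituted 1,3-benzoxazol-2-yl group there is no such gain, with a number 6.8 percentage points higher from compound 1 to compound 4 (within the scatter), so compound 1 and compound 4 cannot be told apart, and a fused two-ring group on this sulfur is evidently not needed for a high read-out among these compounds. No measurement shown here explains why the read-out responds in this way to the group on the sulfur.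

As far as these compounds go, it remains open whether the triazole ring needs its methyl group, and whether a non-aromatic group on the sulfur, such as a 2-aminoethyl chain or a carboxymethyl group, would keep the read-out this high. Each number also describes only one concentration, which leaves open how compound 1 and compound 4 compare in potency.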